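Series notes: methoxy in place of hydrogen on a phenyl ring

The source may report more compounds than this note shows. Statements on the series, on what has been measured and on what is new or still open speak of the compounds shown alone.

compound 1 `CSc1nn(-c2ccccc2)c2ncnc(N/N=C/c3ccc(Cl)cc3)c12` 12.1 nM
compound 2 `CSc1nn(-c2ccccc2)c2ncnc(N/N=C/c3ccccc3O)c12` 10.7 nM

In a functional assay on MCF7 cells (Homo sapiens) for inhibition, read by sulforhodamine B assay, with a stated time of 48 h (on this read-out lower numbers stand for stronger inhibition and higher numbers for weaker inhibition), compound 1 gives 12.1 nM and compound 2 gives 10.7 nM. Compound 2 stands level with compound 1; the step of a 1.1-fold lower number from compound 1 to compound 2 (0.05 log units; within the scatter) is within the scatter. Compound 3 `COc1ccc(-n2nc(SC)c3c(N/N=C/c4ccccc4O)ncnc32)cc1` carries methoxy in place of hydrogen on an aromatic carbon. Going by the values given here, no measured step touches this ring: the single step known concerns the other phenyl ring and is within the scatter, so it offers no guide here. The step of a 1.1-fold lower number from compound 2 to compound 3 (0.03 log units; within the scatter) is therefore expected to stay within the scatter. Compound 3 is estimated at 10 nM in this assay, with a range from 4 nM to 25 nM.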

Compound 3, half-maximal inhibitory concentration: 13.3 nM
For compound 3 the middle estimate is 1.3-fold (0.12 log units) below the measured one; low and high end bracket the measured number.
By their numbers in this assay, from the lowest: compounds 2, 1 and 3 (each within the scatter of the next).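

In this assay, going by these compounds alone, the change from phenyl to 4-methoxyphenyl gives a 1.2-fold higher number from compound 2 to compound 3 (0.09 log units; within the scatter) at this ring, the first reading at this position. With the 2-hydroxyphenyl group held in place, the position therefore takes methoxy, para to a large group, with no step beyond the scatter. Going by these compounds, whether an amine, a carboxylic acid or a longer chain such as butoxy at the same place would stay as close to compound 2 remains open, as does methoxy here alongside the 4-chlorophenyl group of compound 1. No evidence at hand accounts for this step.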